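This account rests on a few compounds, and the source may have more. Where it says the series, first, only, none or still open, it means among the compounds named here.

Measured so far in an ADME assay on Vero cells (Chlorocebus sabaeus) for cytotoxicity (a higher number here means that more compound is tolerated, a lower number that less compound is tolerated), are these two compounds:
- compound 1 `COC(=O)N[C@@H](CSC(C)(C)C)C(=O)N1CCC[C@H]1c1ncc(-c2ccc(-c3ccc(-c4cnc([C@@H]5CCCN5C(=O)[C@@H](NC(=O)OC)C(C)C)[nH]4)cc3)cc2)[nH]1` with 39000 nM
- compound 2 `COC(=O)N[C@@H](CCSC)C(=O)N1CCC[C@H]1c1ncc(-c2ccc(-c3ccc(-c4cnc([C@@H]5CCCN5C(=O)[C@@H](NC(=O)OC)C(C)C)[nH]4)cc3)cc2)[nH]1` with 40000 nM

Within the data shown here, compound 1 has only this one measured neighbour, and the two sit level within the scatter. Compound 3 `COC(=O)N[C@@H](C[S+]([O-])Cc1ccccc1)C(=O)N1CCC[C@H]1c1ncc(-c2ccc(-c3ccc(-c4cnc([C@@H]5CCCN5C(=O)[C@@H](NC(=O)OC)C(C)C)[nH]4)cc3)cc2)[nH]1` is not yet measured and differs from compound 1 at the same chain carbon that differs in compound 2. The change is a group of 9 heavy atoms (7 carbon, 1 oxygen, 1 sulfur; one six-membered aromatic ring of carbon only) in place of a group of 5 heavy atoms (4 carbon, 1 sulfur; no ring), on a saturated chain carbon, two bonds along the chain from an amide-type nitrogen and a carbonyl carbon and it is larger than the measured one. Among the measured compounds shown here, the only step that bears on it is a 1.0-fold higher number from compound 1 to compound 2 (0.01 log units; within the scatter) and it tells little about a group with a six-membered aromatic ring of carbon only, since no measured compound has one at this place. In this assay the expected step is a 1.1-fold lower number from compound 1 to compound 3 (0.05 log units; within the scatter) and no shift beyond the scatter is expected in either direction. For compound 3 the estimate is 35000 nM with an expected range from 14000 nM to 80000 nM as a wide allowance.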

Compound 3, half-maximal cytotoxic concentration: 11000 nM
Estimate against measurement, compound 3: 3.2-fold (0.50 log units) above, outside the stated range (below it).
By their numbers in this assay, from the lowest: compound 3; then compounds 1 and 2 (each within the scatter of the next).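

In this assay this position proves sensitive to what it carries: the group with a six-membered aromatic ring of carbon only gives a 3.5-fold lower number from compound 1 to compound 3 (0.55 log units; beyond the scatter) and a 3.6-fold lower number from compound 2 to compound 3 (0.56 log units; beyond the scatter) whereas the two groups without a ring gave no separable difference. On this saturated chain carbon, then, less compound is tolerated with the larger ring-bearing group than with (tert-butyl)sulfanyl or (methylsulfanyl)methyl. No supporting data are available to explain this shift.

The entering group adds the ring, an oxygen and extra heavy atoms all at once, so the compounds shown cannot tell which of these matters, and a benzylsulfanyl group, with the ring but no oxygen, would help to separate them. As far as these compounds go, how an amine or a carboxylic acid on this chain carbon would behave also remains open.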